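Benzoxazole replaces the ethoxy-methylphenyl terminus in a fatty acid receptor series

This account rests on a few compounds, and the source may have more. Where it says the series, first, only, none or still open, it means among the compounds named here.

Measured compounds:
compound 1 `CCOc1ccc(C)c(-c2cccc(COc3ccc(OCC(=O)O)c(F)c3)c2)c1`, 220 nM
compound 2 `Cc1ccc(OCC2CCCC2)cc1-c1cccc(COc2ccc(OCC(=O)O)c(F)c2)c1`, 490 nM

Compound 1 gives the lowest of the two numbers in a functional assay on CHO cells for agonist activity at Free fatty acid receptor 1 (Homo sapiens), read by FLIPR and calcium flux; on this read-out higher numbers stand for an effect only at larger amounts of compound and lower numbers for an effect already at smaller amounts; its nearest neighbour is compound 2, reached by a 2.2-fold higher number from compound 1 to compound 2 (0.35 log units; beyond the scatter), a modest step in which cyclopentyl takes the place of methyl on a saturated chain carbon bound to an oxygen on an aromatic ring.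

Compound 3 `O=C(O)COc1ccc(OCc2cccc(-c3ccc4ncoc4c3)c2)cc1F` has not yet been measured in this assay. It differs from compound 1 as follows: 1,3-benzoxazol-6-yl in place of 5-ethoxy-2-methylphenyl on an aromatic carbon. The terminal aryl group is exchanged entirely, on an aromatic carbon of a six-membered aromatic ring of carbon only, meta to a large group.

Going by the values given here, the only measured step, from compound 1 to compound 2, touches the same terminal aryl group but alters just its ether substituent, so it bears only loosely on the exchange of the whole ring. It shows the terminus tolerates modest variation at a modest cost. Compound 3 is therefore expected to lose some potency, with an estimated step of a 2.0-fold higher number from compound 1 to compound 3 (0.31 log units; beyond the scatter). Compound 3 is estimated at 450 nM, within the range 150 nM to 1400 nM.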

Compound 3, half-maximal effective concentration: 3240 nM
Compound 3: middle estimate off by 7.2-fold (0.86 log units), on the low side; the whole stated range lies below it.
By their numbers in this assay, from the lowest: compound 1; then compound 2; then compound 3.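

In this assay, exchanging the whole terminal group costs far more than altering its ether substituent: the exchange gives a 15-fold higher number from compound 1 to compound 3 (1.17 log units; beyond the scatter), whereas the earlier change gives only a 2.2-fold higher number from compound 1 to compound 2 (0.35 log units; beyond the scatter). This aromatic carbon, meta to a large group, therefore accepts a change within the ether substituent of the 5-ethoxy-2-methylphenyl group much better than replacement of that group by 1,3-benzoxazol-6-yl, even though the heavy-atom count hardly moves. Nothing available here identifies which feature of the exchange accounts for the loss.

The exchange removes the ethoxy and methyl groups and brings in a five-membered aromatic ring with 2 hetero atoms in a single step, so the compounds shown cannot separate the contribution of each of these changes. On these data alone, it remains open whether a phenyl group carrying only the ethoxy group, or only the methyl group, would stay closer to compound 1, and whether 1,3-benzothiazol-6-yl, with sulfur in place of the ring oxygen, would fare any differently from compound 3.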